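Cathepsin S series: aminopropyl branch on the diamine linker

The source may report more compounds than this note shows. Statements on the series, on what has been measured and on what is new or still open speak of the compounds shown alone.

Measured so far:
compound 1, `COc1cccc(C(=O)N[C@@H](CCC2CCCCC2)C(=O)NCCN2CCc3cc(F)ccc32)c1` — 2130 nM
compound 2, `COc1cccc(C(=O)N[C@@H](CC(C)(C)C)C(=O)N[C@@H](CCS(C)(=O)=O)CN2CCc3cc(F)ccc32)c1` — 14 nM

In an assay on isolated protein for inhibition of cathepsin S (Homo sapiens) (a higher number here means a weaker inhibitor, a lower number a stronger inhibitor), compound 1 stands at the higher of the two numbers, 2130 nM. Compound 2 differs from compound 1 at several places. In this assay compound 2 gives 14 nM, and the gap between the two is beyond the scatter.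

Compound 3, `COc1cccc(C(=O)N[C@@H](CCC2CCCCC2)C(=O)N[C@@H](CCCN)CN2CCc3cc(F)ccc32)c1`, is not yet measured. It differs from compound 1 by 3-aminopropyl in place of hydrogen on a saturated chain carbon bound to an amide-type nitrogen and a saturated chain carbon. Within the data shown here, no measured pair isolates this single change, so the step has to be estimated. Compound 3 is expected to land at a lower number than compound 1, because compound 2, which also carries a side chain on the saturated chain carbon bound to the amide-type nitrogen, gives 14 nM in this assay. The expected step of a 36-fold lower number from compound 1 to compound 3 (1.55 log units; beyond the scatter) is large and downward. Compound 3 is estimated at 60 nM, within 10 nM to 400 nM.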

Compound 3, inhibition constant: 76 nM
Compound 3: middle estimate off by 1.3-fold (0.10 log units), on the low side; the measured number falls inside the stated range.
By their numbers in this assay, from the lowest: compound 2; then compound 3; then compound 1.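

In this assay the 3-aminopropyl group in place of hydrogen on a saturated chain carbon bound to an amide-type nitrogen and a saturated chain carbon gives a 28-fold lower number from compound 1 to compound 3 (1.45 log units; beyond the scatter) with the rest of compound 1 unchanged. This ties a stronger inhibitor to substitution at this carbon alone, which compound 1 and compound 2 could not show, as they differ at several places. Nothing measured here gives a reason for the step.

The compounds shown do not separate the amine of the 3-aminopropyl group from its carbon chain, so a plain propyl group, a chain ending in a hydroxyl group or a carboxylic acid on the same carbon would be the telling comparison. On these data alone, how the number depends on chain length also stays open, whether with a shorter aminoethyl chain or a longer aminobutyl chain.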